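Amide-bearing saturated rings on a fused pyrimidine core

The source may hold more compounds than are shown below. What is called first, only, known or untested is meant among the compounds shown, and "the series" means these compounds.

Measured so far:
compound 1 `NC(=O)CN1CCN(c2nc(-c3cccnc3)nc3c2CN(Cc2ccccc2)CC3)CC1`: 100000 nM
compound 2 `CC(=O)NCCCNc1nc(-c2ccccn2)nc2c1CN(Cc1ccc(F)cc1)CC2`: 200 nM
compound 3 `Cc1cc(C)c2cc(C#N)c(N3CCN(C(=O)c4ccncc4)CC3)nc2c1`: 100000 nM

In an assay on cells with Cystic fibrosis transmembrane conductance regulator variant F508del (Homo sapiens) as the target, read by fluorescence, with stated times of 24 h and 30 min (a higher number here means that more compound is needed for the effect, a lower number that less compound is needed), compound 1 gives 100000 nM, level with compound 3 at the digits shown; together these are the highest of the three numbers. Compound 2 lies far lower, a gap well beyond the usual scatter. Going by the values given here, no two measured compounds differ in a single place, so no measured step is available. Compound 4 `NC(=O)C1CCN(c2nc(-c3cccnc3)nc3c2CN(Cc2ccccc2)CC3)CC1` is next: 4-carbamoylpiperidin-1-yl in place of 4-(carbamoylmethyl)piperazin-1-yl on an aromatic carbon. With nothing comparable in hand, the change is expected to stay within the scatter or lower the number only modestly. Compound 4 is expected to give 60000 nM, with a range of 10000 nM to 100000 nM. That corresponds to an expected step of a 1.7-fold lower number from compound 1 to compound 4 (0.22 log units; within the scatter) in this assay.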

Compound 4, half-maximal effective concentration: 100000 nM
Beside the measured number, compound 4's estimate is 1.7-fold (0.22 log units) below it, within the range that was stated.
By their numbers in this assay, from the lowest: compound 2; then compounds 1, 3 and 4 (each within the scatter of the next).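

In this assay, 4-carbamoylpiperidin-1-yl in place of 4-(carbamoylmethyl)piperazin-1-yl on this aromatic carbon gives no change at the digits printed from compound 1 to compound 4 (within the scatter). This first measured step at the position shows that the assay does not separate these two amide-bearing saturated rings, even with one ring nitrogen fewer in compound 4. No available measurement explains why the two groups read alike. Open, on these data alone, is whether a primary amine, a carboxylic acid or a longer chain ending in the amide would read differently at this position on the core of compound 1.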